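The source may report more compounds than this note shows. Statements on the series, on what has been measured and on what is new or still open speak of the compounds shown alone.

Compound 1, `COC(=O)c1cc(-c2cccc(NC(=O)c3ccc(/C=C/C(=O)c4cccc(C(F)(F)F)c4)cc3)c2)on1`: in an ADME assay on Vero cells (Chlorocebus sabaeus) for cytotoxicity, read by MTT assay, with a stated time of 72 h (a higher number here means that more compound is tolerated, a lower number that less compound is tolerated), compound 1 gives only a limit, > 20 ug/mL.
Compound 2, `COC(=O)c1cc(-c2cccc(NC(=O)c3ccc(/C=C/C(=O)c4ccc(OC)cc4OC)cc3)c2)on1`: in this assay compound 2 gives only a limit, > 50 ug/mL.
Compound 3, `COC(=O)c1cc(-c2cccc(NC(=O)c3ccc(/C=C/C(=O)c4ccc(F)cc4)cc3)c2)on1`: in this assay compound 3 gives only a limit, > 20 ug/mL.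

Compound 3 therefore stands nowhere in particular on these numbers: its value is a limit, and the two other values shown are limits as well. The three measured steps are all unreadable for that reason: a step that the two limits leave unreadable from compound 1 to compound 3, a step that the two limits leave unreadable from compound 2 to compound 3 and a step that the two limits leave unreadable from compound 1 to compound 2. Two of the values sit at the same limit, (the limit of > 20 ug/mL in this assay, at which 2 of the 3 values shown sit), and one at a higher one, (the limit of > 50 ug/mL in this assay, at which 1 of the 3 values shown sits).

Compound 4, `COC(=O)c1cc(-c2cccc(NC(=O)c3ccc(/C=C/C(=O)c4ccc(OC)c([N+](=O)[O-])c4)cc3)c2)on1`, differs from compound 3 at one place: 4-methoxy-3-nitrophenyl in place of 4-fluorophenyl on a carbonyl carbon. Among the measured compounds shown here, none of the measured steps gives a readable size for a change at the carbonyl carbon, so no direction can be drawn from them. The step is therefore expected to stay hidden, and a step that the limit leaves unreadable from compound 3 to compound 4 is what that expectation means. Compound 4 is expected to give about 30 ug/mL in this assay, within 15 ug/mL to 60 ug/mL, most likely again as a limit.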

Compound 4, half-maximal cytotoxic concentration: > 40 ug/mL
Compound 4: only a limit was reported; the forecaster's own chance of this, stated with the estimate: 75%; middle value at least 1.3-fold (0.12 log units) away from the limit.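

In this assay compound 4 gives only a limit, > 40 ug/mL. Its steps to compound 1, compound 2 and compound 3, whose values are also limits, cannot be read. The compounds shown leave open how much of each is tolerated in this assay, and whether the group on the carbonyl carbon changes that at all.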